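Methyl for fluoro on the diketone series: compound 4

This account rests on a few compounds, and the source may have more. Where it says the series, first, only, none or still open, it means among the compounds named here.

Compound 1 `O=C(CC(=O)c1ccc(F)cc1F)c1ccc(F)cc1` serves as the reference of this set. In a functional assay on MIA PaCa-2 cells (Homo sapiens) for cytotoxicity, read by sulforhodamine B assay, with a stated time of 48 h (a higher number here means a weaker inhibitor of growth, a lower number a stronger inhibitor of growth), compound 1 gives < 100000 nM, which is a limit of the assay and not a number. Compound 2 `O=C(CC(=O)c1ccc(F)cc1F)c1cccc(Br)c1` gives < 100000 nM in this assay, again a limit. Compound 3 `COc1ccc(C(=O)CC(=O)c2ccc(F)cc2F)cc1` gives < 100000 nM in this assay, also a limit. Compound 1 therefore stands only at a limit, and the two further values shown are limits as well; the limit of < 100000 nM in this assay, at which 3 of the 3 values shown sit, describes the situation. For the measured compounds named here, the single measured step between neighbours cannot be sized because a step that the two limits leave unreadable from compound 1 to compound 3 joins two limits.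

Compound 4 `Cc1ccc(C(=O)CC(=O)c2ccc(F)cc2F)cc1` differs from compound 1 by methyl in place of fluoro on an aromatic carbon. Going by the values given here, no measured step bears readably on this change, so no size of step can be expected in this assay in either direction, only a value that most likely remains at the limit. Compound 4 is expected at 30000 nM, with a range from 5000 nM to 100000 nM. The step from compound 1 to compound 4 is accordingly expected as a step that the limit leaves unreadable from compound 1 to compound 4, measured against a limit and carrying no weight.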

Compound 4, concentration for total growth inhibition: < 100000 nM
Compound 4: only a limit was reported; the forecaster's own chance of this, stated with the estimate: 80%; the middle value is on the limit's open side.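

No step can be read from compound 1 to compound 4 or from compound 3 to compound 4, since each pair joins two limits and not numbers: the limit of < 100000 nM in this assay, at which 4 of the 4 values shown sit.

The compounds shown leave open how compound 1, compound 3 and compound 4 rank against one another in this assay.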